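The source may hold more compounds than are shown below. What is called first, only, known or untested is meant among the compounds shown, and "the series" means these compounds.

Working notes on the series, read in a functional assay on HCT-116 cells (Homo sapiens) for antiproliferative activity, read by MTT assay, with a stated time of 72 h (on this read-out lower numbers stand for stronger inhibition and higher numbers for weaker inhibition), throughout. Compound 1 (`C=CC(=O)N1CCC(Cc2ccccc2)CC1`) gives > 30000 nM as a limit of the assay and not a number. Compound 2 (`C=CC(=O)Nc1scc(-c2ccccc2)c1C(=O)OCC`) gives > 30000 nM as a limit as well. Compound 3 (`C=CC(=O)N(CC(=O)OCC)c1nc(-c2ccccc2)cs1`) gives > 30000 nM as a limit too, so it has no rank of its own among the three (the limit of > 30000 nM in this assay, at which 3 of the 3 values shown sit).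

Compound 4 (`C=CC(=O)N(CC(=O)NC1COC1)c1nc(-c2ccccc2)cs1`) keeps the core of compound 3 and carries (oxetan-3-yl)amino in place of ethoxy on a carbonyl carbon. Within the data shown here, no step between measured compounds is available to size this change. In this assay the expectation is no shift beyond the scatter, with a small gain in inhibition as the only plausible direction. That expectation rests on compound 3 with > 30000 nM as its limit and on nothing else. The expected move is a number no higher from compound 3 to compound 4 (the limit leaves the size open) and remains an estimate. For compound 4 the estimated value is 30000 nM with an expected range of 10000 nM to 60000 nM and a reading at the limit of the assay as the likeliest outcome.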

Compound 4, half-maximal inhibitory concentration: 20800 nM
Estimate against measurement, compound 4: 1.4-fold (0.16 log units) above; low and high end bracket the measured number.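

In this assay compound 4 gives 20800 nM as a number and not a limit, the only such reading among the compounds shown. Placing (oxetan-3-yl)amino in place of ethoxy on a carbonyl carbon gives an at least 1.4-fold lower number from compound 3 to compound 4 (0.15 log units; that floor lies within the scatter) as the first step read at this position. That step has a floor but no fixed size because compound 3 sits at a limit of the assay: the limit of > 30000 nM in this assay, at which 3 of the 4 values shown sit.

Still open, from the compounds shown here alone, is whether the number goes with the amide hydrogen or with the four-membered ring, a question that a plain methylamino group or a carboxylic acid on the same carbonyl carbon would bear on. Also open, going by these compounds, is whether any other group at this position gives a step beyond the scatter.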